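This account rests on a few compounds, and the source may have more. Where it says the series, first, only, none or still open, it means among the compounds named here.

Of the compounds shown here, three have been measured so far.

Compound 1 `CS(=O)(=O)Nc1ccc(NC(=O)c2ccc(C#N)cc2)cc1Cl` gives in an ADME assay on RAW264.7 cells (Mus musculus) for cytotoxicity, read by MTT assay, with a stated time of 48 h (a lower number here means a stronger inhibitor, a higher number a weaker inhibitor), a result of > 250000 nM, which is a limit of the assay rather than a number.
Compound 2 `CS(=O)(=O)Nc1ccc(NC(=O)c2cccc(C(F)(F)F)c2)cc1Cl` gives in this assay a result of > 250000 nM, again a limit of the assay.
Compound 3 `CCS(=O)(=O)Nc1ccc(NC(=O)c2ccc(C#N)cc2)cc1Cl` gives in this assay a result of 226000 nM.

Compound 3 is made from compound 1 by one change: methyl in place of hydrogen on a saturated chain carbon bound to a sulfonyl sulfur. The step this change made is an at least 1.1-fold lower number from compound 1 to compound 3 (0.04 log units; that floor lies within the scatter). That step is known only as a floor due to the limit of > 250000 nM in this assay, at which 2 of the 3 values shown sit; the true step may be larger, but what is seen lies within the usual scatter.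

Compound 2 and compound 1 share the same kind of core with the same sulfonamide and the same chloro substituent, but the difference between the two cores is not broken down here.

Compound 4 `CCS(=O)(=O)Nc1ccc(NC(=O)c2cccc(C(F)(F)F)c2)cc1Cl` is not yet measured. It stands to compound 2 as compound 3 stands to compound 1, through the same change: methyl in place of hydrogen on a saturated chain carbon bound to a sulfonyl sulfur. The places of the two changes read word for word alike, so the change is of the same kind.

For compound 4 the expected step in this assay is a number no higher from compound 2 to compound 4 (the limit leaves the size open), a step about as small as the measured one from compound 1 to compound 3. That expectation rests on compound 2 standing at the limit > 250000 nM and on the measured step of an at least 1.1-fold lower number from compound 1 to compound 3 (0.04 log units; that floor lies within the scatter), which did not move compound 3 far from the same limit. Compound 4 is therefore estimated at 250000 nM, most likely between 150000 nM and 400000 nM, with a real chance that only a limit is reported.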

Compound 4, half-maximal inhibitory concentration: 62400 nM
The estimate for compound 4 lay 4.0-fold (0.60 log units) above the measured number; the whole stated range lies above it.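

In this assay, the same swap of methylsulfonyl for ethylsulfonyl that gave only a small floor on the first core now gives a clear result on the second: an at least 4.0-fold lower number from compound 2 to compound 4 (0.60 log units; beyond the scatter). This shows that the change can lower the number on the core of compound 2 by more than ordinary scatter, but it does not show whether the two cores respond differently, and one step on each core is too little to make a rule for the series: the same change on two cores in this assay, an at least 1.1-fold lower number (0.04 log units; that floor lies within the scatter) from compound 1 to compound 3 and an at least 4.0-fold lower number (0.60 log units; beyond the scatter) from compound 2 to compound 4; the limit leaves it open whether they differ Compound 1 and compound 2 both stand at a limit of the assay and not at a number, so the true size of each step stays unknown: the limit of > 250000 nM in this assay, at which 2 of the 4 values shown sit.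

The compounds shown leave open whether a longer chain in place of the ethyl would lower the number further, and whether the step would hold on a core carrying an amine or a carboxylic acid in place of the nitrile or the trifluoromethyl. Also open, from the compounds shown here alone, is how compound 1 and compound 2 compare with each other, and with that how much the core itself contributes to the number.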